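Moving the Methoxy Group from Compound 2 to Compound 4

This account rests on a few compounds, and the source may have more. Where it says the series, first, only, none or still open, it means among the compounds named here.

Three compounds share one core and have been measured in a functional assay on RPMI-8226 cells (Homo sapiens) for inhibition, read by sulforhodamine B assay, with a stated time of 48 h, tested at 10 uM; a higher number here means more inhibition at the concentration tested (going by the name of the read-out), a lower number less inhibition:
compound 1 `Brc1cn2ccnc2c(-c2ccc3ncn(C4CCCCC4)c3c2)n1` gives 14.9%;
compound 2 `COc1ccc(-c2cn3ccnc3c(-c3ccc4ncn(C5CCCCC5)c4c3)n2)cc1` gives 95.6%;
compound 3 `Clc1ccc(-c2cn3ccnc3c(-c3ccc4ncn(C5CCCCC5)c4c3)n2)cc1` gives 19%.

Compound 2 stands highest of the three numbers. Its nearest neighbour is compound 3, with a number 76.6 percentage points lower from compound 2 to compound 3 (beyond the scatter), and the furthest is compound 1, with a number 80.7 percentage points higher from compound 1 to compound 2 (beyond the scatter). Both steps are large and beyond the scatter, and in both the 4-methoxyphenyl side of the pair is the high one; the bromo and 4-chlorophenyl compounds lie close to one another, a number 4.1 percentage points higher from compound 1 to compound 3 (within the scatter).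

Compound 4 `COc1ccccc1-c1cn2ccnc2c(-c2ccc3ncn(C4CCCCC4)c3c2)n1` keeps every atom of compound 2 but joins them differently: 2-methoxyphenyl in place of 4-methoxyphenyl on an aromatic carbon. Among the compounds with values here, no measured step moves the methoxy around the ring, so none bears directly on this change. The measured steps only show that the 4-methoxyphenyl group carries the high number, and that exchanging it for other groups cost a great deal. Moving the methoxy is therefore a step of unknown size; a drop is considered more likely than a rise, but the outcome is wide open.

Compound 4 is expected to give 60%, within a range from 20% to 96%. That estimate means an expected step of a number 35.6 percentage points lower from compound 2 to compound 4 (beyond the scatter).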

Compound 4, a percentage reported as inhibition, at one concentration (the size of the read-out at that concentration, not a potency): 35.9%
Estimate against measurement, compound 4: 24.1 percentage points above; the measured number falls inside the stated range.
By their numbers in this assay, from the lowest: compounds 1 and 3 (each within the scatter of the next); then compound 4; then compound 2.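

In this assay the position of the methoxy matters on its own: with the same atoms joined differently, the step is a number 59.7 percentage points lower from compound 2 to compound 4 (beyond the scatter) and shows that the high number belongs to the 4-methoxyphenyl group, not to methoxyphenyl as such. Compound 4 does not fall back to the low pair, with steps of a number 16.9 percentage points higher from compound 3 to compound 4 (beyond the scatter) and a number 21 percentage points higher from compound 1 to compound 4 (beyond the scatter) placing it between those compounds and compound 2. Nothing available explains the difference between the two methoxy placements.

The compounds shown leave open whether another group in place of the methoxy on the 4-methoxyphenyl ring, such as an amine or a longer ether chain, would keep the high number. From the compounds shown here alone, each compound was read at one concentration only, so how their potencies compare also remains open.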